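Series notes: shortening the ketone chain toward acetyl

This account rests on a few compounds, and the source may have more. Where it says the series, first, only, none or still open, it means among the compounds named here.

Within the data shown here, compound 3 `COc1cc(C(=O)O)ccc1OCCCCOc1ccc(C(=O)CC(C)(C)C)c(O)c1C` stands highest of the three measured members in an assay on HEK293 cells for positive allosteric modulation of metabotropic glutamate receptor 3 (Rattus norvegicus), read by thallium flux, with a stated time of 2.5 min (on this read-out higher numbers stand for larger maximal responses and lower numbers for smaller maximal responses), giving 109%. Compound 1 `COc1cc(C(=O)O)ccc1OCCCCOc1ccc(C(=O)CC(C)C)c(O)c1C` gives 73.9% and compound 2 `CC(=O)c1ccc(OCCCCOc2ccc(C(=O)O)cc2C)c(C)c1O` gives 25.4%. Compound 4 `COc1cc(C(=O)O)ccc1OCCCCOc1ccc(C(C)=O)c(O)c1C` is not yet measured; it differs from compound 3 by hydrogen in place of tert-butyl on a saturated chain carbon bound to a carbonyl carbon. Among the measured compounds shown here, the only measured step that bears on this part of the structure is a number 35.1 percentage points higher from compound 1 to compound 3 (beyond the scatter), where adding a methyl on the chain raised the maximal response. Compound 2 carries an acetyl ketone but also a different core, so against compound 3 only the two values themselves can be set side by side. Removing the whole tert-butyl is therefore expected to lower the response, with a step of a number 69 percentage points lower from compound 3 to compound 4 (beyond the scatter). Compound 4 is expected to give 40%, between 15% and 70%.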

Compound 4, largest response reached (reported as percent of maximum), in percent of the reference or control that the assay uses: 26.3%
The estimate for compound 4 lay 13.7 percentage points above the measured number; the range from low to high includes it.
By their numbers in this assay, from the lowest: compounds 2 and 4 (each within the scatter of the next); then compound 1; then compound 3.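

In this assay, loss of the whole tert-butyl is large (a number 82.7 percentage points lower from compound 3 to compound 4 (beyond the scatter)), and loss of the isopropyl is also large (a number 47.6 percentage points lower from compound 1 to compound 4 (beyond the scatter)), so the acetyl ketone stands beyond the scatter below both branched ketones. With the acetyl ketone held fixed, methoxy in place of methyl on an aromatic carbon stays within the scatter (a number 0.9 percentage points higher from compound 2 to compound 4 (within the scatter)). No measurement here explains these steps.

From the compounds shown here alone, whether a longer unbranched chain or a cyclohexyl ring on the ketone would keep the response stays open. So does whether methoxy and methyl also match with the neopentylcarbonyl ketone.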